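Swapping Propoxy for Methylsulfanyl at an Aromatic Carbon

This account rests on a few compounds, and the source may have more. Where it says the series, first, only, none or still open, it means among the compounds named here.

Compound 1 `CCCc1nc2cccc(C(=O)O)c2n1Cc1ccc(-c2ccccc2-c2noc(O)n2)cc1` gives 88% in a functional assay on the whole organism for inhibition, with Rattus norvegicus as the target, with a stated time of 7 h, at a dose of 1 mg/kg by the oral route; on this read-out lower numbers stand for less inhibition and higher numbers for more inhibition at the one dose given (going by the name of the read-out).
Compound 2 `CCCOc1nc2cccc(C(=O)O)c2n1Cc1ccc(-c2ccccc2-c2noc(O)n2)cc1` gives 100% in this assay.

Compound 2 stands highest of the two numbers, with a number 12 percentage points higher from compound 1 to compound 2 (beyond the scatter). Compound 3 `CSc1nc2cccc(C(=O)O)c2n1Cc1ccc(-c2ccccc2-c2noc(O)n2)cc1` differs from compound 2 in one place: methylsulfanyl in place of propoxy on an aromatic carbon. Going by the values given here, the single measured step alters the group at this same aromatic carbon, yet it involves propyl rather than methylsulfanyl, so it bears on the new change only loosely. Because compound 2 gives 100%, no rise is possible, and compound 3 is expected to show a number 15 percentage points lower from compound 2 to compound 3 (beyond the scatter), a modest fall at most. Compound 3 is estimated at 85%, between 60% and 100%.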

Compound 3, a percentage reported as inhibition, in the whole organism at one dose (the size of the read-out at that dose, not a potency): 100%
The estimate for compound 3 lay 15 percentage points below the measured number, and the stated range covers the measured number.
By their numbers in this assay, from the lowest: compound 1; then compounds 2 and 3 (each within the scatter of the next).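

Methylsulfanyl in place of propoxy gives no change at the digits printed from compound 2 to compound 3 (within the scatter) in this assay, so at this aromatic carbon between two ring nitrogen atoms the read-out holds with the shorter sulfur-linked group. Methylsulfanyl in place of propyl gives a number 12 percentage points higher from compound 1 to compound 3 (beyond the scatter), a step that matches the one seen with propoxy. Nothing given here explains either result. As far as these compounds go, whether an amine or a longer sulfur-linked chain at this carbon would hold the read-out remains open. Any difference between compound 2 and compound 3 at a lower dose also remains open.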